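Adding an Amino Group to the Anilino Ring

The source may hold more compounds than are shown below. What is called first, only, known or untested is meant among the compounds shown, and "the series" means these compounds.

Measured compounds:
compound 1 `O=S(=O)(c1ccccc1)c1nc2ccccc2nc1Nc1ccccc1` — 590 nM
compound 2 `COc1cc(Nc2nc3ccccc3nc2S(=O)(=O)c2ccccc2)cc(OC)c1OC` — 29100 nM
compound 3 `Cc1ccc(S(=O)(=O)c2nc3ccccc3nc2Nc2ccccc2)cc1` — 1060 nM

All three share one core and were tested in a functional assay on PC-3 cells (Homo sapiens) for cytotoxicity, read by MTT assay, with a stated time of 72 h; on this read-out higher numbers stand for weaker inhibition and lower numbers for stronger inhibition. Compound 3 gives 1060 nM, the second highest of the three numbers. Among the compounds with values here, its nearest neighbour is compound 1, and the only single-place step among the measured compounds, a 1.8-fold higher number from compound 1 to compound 3 (0.25 log units; within the scatter), stays within the scatter. The furthest is compound 2, which sits beyond the scatter from compound 3.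

Compound 4 `Cc1ccc(S(=O)(=O)c2nc3ccccc3nc2Nc2cccc(N)c2)cc1` differs from compound 3 by amino in place of hydrogen on an aromatic carbon, on an aromatic carbon of a six-membered aromatic ring of carbon only, meta to a large group. Within the data shown here, no measured step adds a single group to this ring, so nothing bears on the change directly. The only hint comes from the anilino ring carrying three methoxy groups at once: compound 1 gives 590 nM while compound 2 gives 29100 nM. A single amino group is a much smaller change, so only a modest weakening is expected. The expected step of a 1.5-fold higher number from compound 3 to compound 4 (0.18 log units; within the scatter) is therefore small. Compound 4 is estimated at 1600 nM, within 500 nM to 6000 nM.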

Compound 4, half-maximal inhibitory concentration: 2000 nM
For compound 4 the middle estimate is 1.3-fold (0.10 log units) below the measured one; the measured number falls inside the stated range.
By their numbers in this assay, from the lowest: compounds 1, 3 and 4 (each within the scatter of the next, the first and the last beyond it); then compound 2.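

In this assay, the change from phenyl to 3-aminophenyl gives a 1.9-fold higher number from compound 3 to compound 4 (0.28 log units; within the scatter) as the only single-place step on this ring among the compounds shown. The step shows that an amino group can sit on an aromatic carbon of this ring, meta to a large group, without moving the number beyond the scatter. No measured evidence is available to explain this outcome. The compounds shown leave open whether an amino group at other places on this ring would give a similar number. Also open, on these data alone, is how a hydroxyl group or a carboxylic acid would compare in this same place, and whether a longer chain on the amino nitrogen would keep the number within the scatter.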